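Moving the methylsulfanyl group: an expected small step

The source may report more compounds than this note shows. Statements on the series, on what has been measured and on what is new or still open speak of the compounds shown alone.

Measured in a functional assay on SK-OV-3 cells (Homo sapiens) for antiproliferative activity, read by MTT assay, with a stated time of 72 h; a higher number here means a weaker inhibitor, a lower number a stronger inhibitor:
- compound 1 `C#Cc1cccc(NC(=O)CCc2cccc3c2B(O)OC3)c1`: 980 nM
- compound 2 `O=C(CCc1cccc2c1B(O)OC2)Nc1cccc(-c2ccc(Cl)cc2)c1`: 220 nM
- compound 3 `CSc1cccc(-c2cccc(NC(=O)CCc3cccc4c3B(O)OC4)c2)c1`: 150 nM

Compound 3, at 150 nM, sits with compound 2, at 220 nM, at the low end of the three numbers. The two are not separated, as a 1.5-fold lower number from compound 2 to compound 3 (0.17 log units; within the scatter) shows. Compound 1 lies well apart, as a 6.5-fold lower number from compound 1 to compound 3 (0.82 log units; beyond the scatter) shows.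

Compound 4 `CSc1ccc(-c2cccc(NC(=O)CCc3cccc4c3B(O)OC4)c2)cc1` carries 4-(methylsulfanyl)phenyl in place of 3-(methylsulfanyl)phenyl on an aromatic carbon. Going by the values given here, the two compounds have the same atoms, joined differently, and no measured step makes this exact change.

The nearest evidence is the exchange of one substituted phenyl for another, a 1.5-fold lower number from compound 2 to compound 3 (0.17 log units; within the scatter). The larger steps, a 4.5-fold lower number from compound 1 to compound 2 (0.65 log units; beyond the scatter) and a 6.5-fold lower number from compound 1 to compound 3 (0.82 log units; beyond the scatter), both replace ethynyl and so speak to a different change. Among the compounds with values here, they show only that both substituted phenyl groups gave lower numbers than ethynyl did. On this evidence, the expected step in this assay is a 1.2-fold higher number from compound 3 to compound 4 (0.08 log units; within the scatter), with no shift beyond the scatter expected in either direction. The estimate for compound 4 is 180 nM, with an expected range of 80 nM to 400 nM.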

Compound 4, half-maximal inhibitory concentration: 140 nM
Compound 4: the middle estimate sits 1.3-fold (0.11 log units) above what was measured; the range from low to high includes it.
By their numbers in this assay, from the lowest: compounds 4, 3 and 2 (each within the scatter of the next); then compound 1.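

Exchanging 3-(methylsulfanyl)phenyl for 4-(methylsulfanyl)phenyl gave a step within the scatter in this assay (a 1.1-fold lower number from compound 3 to compound 4 (0.03 log units; within the scatter)), so the earlier exchange between two differently substituted phenyl groups now has a direct counterpart in which only the place of the methylsulfanyl group differs. Methylsulfanyl in place of chloro also stayed within the scatter (a 1.6-fold lower number from compound 2 to compound 4 (0.20 log units; within the scatter)), while the step from ethynyl lay beyond it (a 7.0-fold lower number from compound 1 to compound 4 (0.85 log units; beyond the scatter)), so all three substituted phenyl groups shown gave lower numbers than ethynyl did and cannot be told apart from one another in this read-out. No accompanying measurement offers an explanation for these results.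

The substituents shown on this phenyl group are limited to methylsulfanyl and chloro, so it remains open whether an amine, a carboxylic acid or a morpholine ring at the same place would also stay within the scatter of compound 4. From the compounds shown here alone, it is also open whether methylsulfonyl or a longer alkylsulfanyl chain in place of methylsulfanyl would leave the number unchanged, or whether the flat picture seen here would hold on other cell lines.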